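A Piperidine Replaces Ethyl on the Amide Carbonyl

The compounds below may be only part of what the source reports. "The series", "measured", "known", "first", "only" and "open" are said of these compounds alone.

Two compounds share a core built around an alkyne-linked phenyl ring. Compound 1 (`Cc1cccc(C#Cc2nc3c(s2)C(=O)NCC3)c1`) carries a methyl on that phenyl ring and an unsubstituted amide in its saturated ring. In an assay on HEK293 cells for positive allosteric modulation of metabotropic glutamate receptor 5 (Homo sapiens), read by FLIPR, with a stated time of 1 h (a lower number here means that less compound is needed, a higher number that more compound is needed for the effect), compound 1 reaches only a limit of the assay, > 10000 nM. Compound 2 (`CCC(=O)N1CCc2nc(C#Cc3ccccc3)sc2C1`) instead has a propanoyl group on the ring nitrogen. In this assay compound 2 also reaches only a limit, > 10000 nM. Both values shown sit at that limit (the limit of > 10000 nM in this assay, at which 2 of the 2 values shown sit), so no number has yet been found for this series.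

Compound 3 (`O=C(N1CCCCC1)N1CCc2nc(C#Cc3ccccc3)sc2C1`) differs from compound 2 in one place: piperidin-1-yl in place of ethyl on a carbonyl carbon. Among the compounds with values here, with both measured values stopping at the limit, there is no measured step to guide the size of this change. The expected step that the limit leaves unreadable from compound 2 to compound 3 is therefore none beyond the scatter, with the chance that compound 3 again shows only a limit judged high. Compound 3 is estimated at 15000 nM, in the range 3000 nM to 100000 nM.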

Compound 3, half-maximal effective concentration: 75 nM
Compound 3: the middle estimate sits 200-fold (2.30 log units) above what was measured; the measured number lies below the stated range.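

In this assay, the group on the carbonyl carbon turns out to decide whether a number can be read at all: piperidin-1-yl in place of ethyl gives a clear change (an at least 130-fold lower number from compound 2 to compound 3 (2.12 log units; beyond the scatter)). Compound 3 is the first compound shown with a measured value rather than a limit, so this series can give a readable result in this assay, and the carbonyl substituent is one place where that result is won or lost. The real size of the step cannot be known, only its minimum, because compound 2 stops at a limit and has no number of its own: the limit of > 10000 nM in this assay, at which 2 of the 3 values shown sit.

As far as these compounds go, what remains open is which feature of the new group matters, the ring or the nitrogen on the carbonyl: cyclohexyl on the same carbonyl carbon would keep a six-membered ring without that nitrogen, while dimethylamino would keep the nitrogen without the ring. Also open, from the compounds shown here alone, is how much room this place allows around the value of compound 3 (75 nM), a question that a smaller pyrrolidin-1-yl or a morpholin-4-yl with its added ring oxygen would address.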